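The source may report more compounds than this note shows. Statements on the series, on what has been measured and on what is new or still open speak of the compounds shown alone.

The compounds share one core, and that core carries a nitrogen on an aromatic ring to which a substituted phenyl is attached; the three measured compounds differ only in that phenyl. Compound 1 `COc1cc2c(Nc3cc(C(F)(F)F)ccc3F)ncnc2c(OC)c1OC` bears a phenyl carrying fluorine and a trifluoromethyl group, compound 3 `COc1cc2c(Nc3ccc(B(O)O)cc3)ncnc2c(OC)c1OC` a phenyl carrying a boronic acid, and compound 2 `COc1cc2c(Nc3ccc(Br)c(F)c3)ncnc2c(OC)c1OC` a 4-bromo-3-fluorophenyl. In a functional assay on SGC-7901 cells (Homo sapiens) for antiproliferative activity, read by MTT assay, with a stated time of 72 h (a lower number here means a stronger inhibitor, a higher number a weaker inhibitor), compound 1 gives 10300 nM and compound 3 gives 434 nM. Compound 2 gives only > 30000 nM, which is a limit of the assay and not a number, as stated in the limit of > 30000 nM in this assay, at which 1 of the 3 values shown sits. Compound 2 therefore sits at the weak end of what has been measured, and compound 3 at the strong end.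

Compound 4 `COc1cc2c(Nc3cccc(F)c3F)ncnc2c(OC)c1OC` has not yet been measured. It differs from compound 2 in a single place: 2,3-difluorophenyl in place of 4-bromo-3-fluorophenyl on a nitrogen on an aromatic ring. Within the data shown here, no measured pair shows this same change, so the size of the step cannot be read from the data. The phenyl of compound 1 likewise carries only fluorine and a trifluoromethyl group, and in this assay compound 1 gives 10300 nM. Compound 2 sits at a limit. The expectation is that compound 4 also stays weak, with the step from compound 2 to compound 4 estimated at an at least 2.0-fold lower number from compound 2 to compound 4 (0.30 log units; that floor lies within the scatter). Compound 4 is expected to give about 15000 nM in this assay, most likely between 4000 nM and 40000 nM.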

Compound 4, half-maximal inhibitory concentration: > 30000 nM
Compound 4 was reported as a limit (the forecaster's own chance of this, stated with the estimate: 45%); middle value at least 2.0-fold (0.30 log units) from the limit.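

No step can be read between compound 2 and compound 4, because each is reported only as a limit of the assay and not as a number: the limit of > 30000 nM in this assay, at which 2 of the 4 values shown sit.

The compounds shown leave open whether 2,3-difluorophenyl and 4-bromo-3-fluorophenyl on this shared core differ at all in this assay, and by how much.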